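Methylsulfonyl for butylcarbonyl on a limit-bound compound

The source may hold more compounds than are shown below. What is called first, only, known or untested is meant among the compounds shown, and "the series" means these compounds.

In a functional assay on L6 cells (Rattus norvegicus) for cytotoxicity, with a stated time of 72 h (a higher number here means a weaker inhibitor, a lower number a stronger inhibitor), compound 1 (`CC(=O)NCC1OC(n2ccc(=O)[nH]c2=O)CC1O`) shows > 335000 nM as a limit of the assay, not as a number. Compound 2 (`CCCCC(=O)NCC1OC(n2ccc(=O)[nH]c2=O)CC1O`) likewise shows > 289000 nM as a limit. Among the measured compounds shown here, compound 2 therefore stands without a readable number, and the only other value beside it is also a limit.

For the measured compounds named here, compound 3 (`CS(=O)(=O)NCC1OC(n2ccc(=O)[nH]c2=O)CC1O`) carries methylsulfonyl in place of butylcarbonyl on an amine nitrogen, and no measured step covers that exchange directly. Going by the values given here, the single measured step (a step that the two limits leave unreadable from compound 1 to compound 2) is the only one that bears on it, and it offers no size to carry forward. Going by the limit of compound 2 (> 289000 nM), this assay is expected to show no clear change for compound 3 and will most likely report a limit again. The expected size is a step that the limit leaves unreadable from compound 2 to compound 3 and nothing beyond the scatter, in either direction. For compound 3 the estimate is 295000 nM with an expected range of 150000 nM to 400000 nM in this reading.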

Compound 3, half-maximal inhibitory concentration: > 295000 nM
Compound 3 gave a limit, no number (the forecaster's own chance of this, stated with the estimate: 90%); the middle value sits exactly at the limit.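

In this assay compound 3 gives > 295000 nM, which is a limit of the assay and not a number. Its steps from compound 1 and compound 2 therefore cannot be read. All three compounds stand at limits, leaving open whether acetyl, butylcarbonyl or methylsulfonyl on the amine nitrogen makes any difference in this assay.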